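Methoxy for methylamino on a furan-2-yl nucleoside core

A few compounds are considered here, and "the series" means these few. Any claim that something is new, unique, unknown or untested is made for them only; others in the source may bear on it.

Measured compounds:
- Compound 1, `COc1ncnc2c1c(-c1ccsc1)cn2[C@@H]1O[C@H](CO)[C@@H](O)[C@H]1O`: 430 nM
- Compound 2, `COc1ncnc2c1c(-c1ccoc1)cn2[C@@H]1O[C@H](CO)[C@@H](O)[C@H]1O`: 290 nM
- Compound 3, `CNc1ncnc2c1c(-c1ccco1)cn2[C@@H]1O[C@H](CO)[C@@H](O)[C@H]1O`: 850 nM

In a functional assay on HepG2 cells (Homo sapiens) for antiproliferative activity, read by XTT assay, with a stated time of 72 h (a higher number here means a weaker inhibitor, a lower number a stronger inhibitor), compound 3 gives 850 nM, the highest of the three numbers. Its gap to compound 1 lies within the scatter, while its gap to compound 2 lies beyond it, so compound 3 is the weaker inhibitor of that pair. The unmeasured compound 4, `COc1ncnc2c1c(-c1ccco1)cn2[C@@H]1O[C@H](CO)[C@@H](O)[C@H]1O`, shares the furan-2-yl group of compound 3 and differs from it in one place: methoxy in place of methylamino on an aromatic carbon.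

Among the compounds with values here, no measured step covers this exchange. Within the data shown here, the only step recorded, a 1.5-fold lower number from compound 1 to compound 2 (0.17 log units; within the scatter), concerns the furan-3-yl in place of thiophen-3-yl and stays within the scatter, so it says nothing about the methylamino-to-methoxy change. What the data offer is that both methoxy compounds, compound 1 and compound 2, sit at lower numbers than compound 3. On that basis compound 4 is expected to show a modest move toward lower numbers, a 1.9-fold lower number from compound 3 to compound 4 (0.28 log units; within the scatter), though a result within the scatter of compound 3 would not surprise. The estimate for compound 4 in this assay is 450 nM, with a range from 200 nM to 1000 nM.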

Compound 4, half-maximal inhibitory concentration: 300 nM
Compound 4: the middle estimate sits 1.5-fold (0.18 log units) above what was measured; the range from low to high includes it.
By their numbers in this assay, from the lowest: compounds 2, 4, 1 and 3 (each within the scatter of the next, the first and the last beyond it).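

In this assay, the exchange of methylamino for methoxy on the aromatic carbon gives a 2.8-fold lower number from compound 3 to compound 4 (0.45 log units; beyond the scatter) with the furan-2-yl group held fixed, so this position responds to the change by more than the usual scatter. With methoxy in place, the aromatic group attached to the shared core matters little here: the data show a 1.0-fold higher number from compound 2 to compound 4 (0.01 log units; within the scatter) and a 1.4-fold lower number from compound 1 to compound 4 (0.16 log units; within the scatter) and both lie within the scatter, so furan-2-yl, furan-3-yl and thiophen-3-yl are not told apart. No independent measurement is available to account for the step from methylamino to methoxy.

The compounds shown leave open whether methoxy and methylamino differ in the same way when furan-3-yl or thiophen-3-yl replaces furan-2-yl. They also leave open how an unsubstituted amine, a dimethylamino group or an ethoxy group would read at this position.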